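Oxazolidinone Amides with Varied Para Substituents

A few compounds are considered here, and "the series" means these few. Any claim that something is new, unique, unknown or untested is made for them only; others in the source may bear on it.

Compound 1, `O=C(CCCCCc1ccc(Cl)cc1)N1CCOC1=O`: 4600 nM
Compound 2, `O=C(CCCCCc1ccc(Br)cc1)N1CCOC1=O`: 8510 nM
Compound 3, `O=C(CCCCCc1ccc(I)cc1)N1CCOC1=O`: > 20000 nM

In an assay on HEK293 cells for inhibition of N-acylethanolamine-hydrolyzing acid amidase (Rattus norvegicus), read by LC-MS, with a stated time of 30 min (on this read-out lower numbers stand for stronger inhibition and higher numbers for weaker inhibition), compound 1 gives 4600 nM and compound 2 gives 8510 nM. For compound 3 the read-out is only a limit of the assay, > 20000 nM, which is the limit of > 20000 nM in this assay, at which 1 of the 3 values shown sits. Compound 3 thus stands at the weak end of the three, since an at least 4.3-fold higher number from compound 1 to compound 3 (0.63 log units; beyond the scatter) and an at least 2.3-fold higher number from compound 2 to compound 3 (0.37 log units; beyond the scatter), while a 1.9-fold higher number from compound 1 to compound 2 (0.27 log units; within the scatter).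

Compound 4, `CSc1ccc(CCCCCC(=O)N2CCOC2=O)cc1`, carries methylsulfanyl in place of iodo on an aromatic carbon. The two steps that end at compound 3 are the ones that bear on it, and both were at least modest in the weakening direction; since the new group is not a halogen, a move back toward a measurable number is estimated, an at least 2.0-fold lower number from compound 3 to compound 4 (0.30 log units; that floor lies within the scatter). Compound 4 is therefore expected to give about 10000 nM, within 3000 nM to 30000 nM.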

Compound 4, half-maximal inhibitory concentration: > 20000 nM
Compound 4: a limit, no number; the forecaster's own chance of this, stated with the estimate: 35%; at least 2.0-fold (0.30 log units) between middle value and limit.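

With methylsulfanyl in place of iodo, para to a large group, the read-out does not return to a measured number: compound 4 gives only a limit of the assay, > 20000 nM. Against the other two halogen compounds the change can be read, with an at least 2.3-fold higher number from compound 2 to compound 4 (0.37 log units; beyond the scatter) and an at least 4.3-fold higher number from compound 1 to compound 4 (0.63 log units; beyond the scatter), while the step from compound 3 cannot be read. Weak inhibition at this position is thus not confined to iodo, and the series now reaches the assay's ceiling twice: the limit of > 20000 nM in this assay, at which 2 of the 4 values shown sit.

As far as these compounds go, how far compound 3 and compound 4 actually lie apart stays open. So does whether fluoro, methoxy or an amine at this position would give a measurable number.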